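This account rests on a few compounds, and the source may have more. Where it says the series, first, only, none or still open, it means among the compounds named here.

Three measured compounds sharing one core have been examined in a functional assay on HepG2 cells (Homo sapiens) for antiproliferative activity, read by MTT assay, with a stated time of 24 h; a higher number here means a weaker inhibitor, a lower number a stronger inhibitor. Compound 1 `C=CCc1cc(-c2ccc(C(F)(F)F)cc2)ccc1O` gives 60300 nM in this assay. Compound 2 `C=CC(C)(C)c1cc(-c2cccc([N+](=O)[O-])c2)ccc1O` gives 56000 nM in this assay, and compound 3 `C=CC(C)(C)c1cc(-c2ccc(OC)cc2)ccc1O` gives 91000 nM. Compound 1 stands among these three numbers without separating from either of the others: its difference from compound 2 and its difference from compound 3 both fall within the usual scatter of repeated measurements, so no ranking among the three can be read from the data. All of them act as weak inhibitors in this assay.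

Compound 4 `C=CCc1cc(-c2ccc(C(F)(F)F)cc2)ccc1OC` has not yet been measured. It differs from compound 1 by a single change: methyl in place of hydrogen on an oxygen on an aromatic ring. Within the data shown here, no measured pair in the set shows the effect of this change, so there is no step to lean on. Given that every number in the set sits in a narrow band, the expectation is that compound 4 will remain in that band or drift slightly toward a higher number, with the step expected at a 1.2-fold higher number from compound 1 to compound 4 (0.09 log units; within the scatter) in this assay, not beyond the scatter. The value of compound 4 in this assay is therefore estimated at 75000 nM, with a range from 35000 nM to 160000 nM.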

Compound 4, half-maximal inhibitory concentration: 89000 nM
Estimate against measurement, compound 4: 1.2-fold (0.07 log units) below; the measured number falls inside the stated range.
By their numbers in this assay, from the lowest: compounds 2, 1, 4 and 3 (each within the scatter of the next).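

Among these compounds, the step from hydroxy to methoxy gives the first reading of this position, and in this assay it reads a 1.5-fold higher number from compound 1 to compound 4 (0.17 log units; within the scatter). Methyl in place of hydrogen on the oxygen on the aromatic ring therefore gives no separation between the two compounds, so within this single pair the hydrogen on that oxygen is not shown to matter for the read-out, though a pair of weak inhibitors may say little about what the position could do in a more active compound. Nothing in the data accounts for the size of this step or tells whether it reflects anything beyond repeated-measurement scatter.

What the compounds shown leave open is whether the same change would read alike on the cores of compound 2 and compound 3, which carry different groups elsewhere, since only one pair speaks to it. They also leave open whether anything larger or different on that oxygen, such as an ethyl or longer chain, an acetyl group or a chain ending in a carboxylic acid, or an amine in place of the hydroxy, would move the number beyond the scatter.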